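A few compounds are considered here, and "the series" means these few. Any claim that something is new, unique, unknown or untested is made for them only; others in the source may bear on it.

Among the compounds with values here, compound 3, with structure `Cc1cccc(F)c1-c1nc(CN2CCC(C(=O)NCCCN3C[C@H](C)C[C@H](C)C3)CC2)c(C)o1`, gives the highest number of the three measured so far in an ADME assay on microsomes from liver (Rattus norvegicus) for metabolic stability, read by LC-MS, using NADPH, at 37 degrees C (a higher number here means that the compound lasts longer, a lower number that the compound disappears faster), at 0.0733 h. Compound 1, with structure `Cc1oc(-c2c(Br)cccc2Br)nc1CN1CCC(C(=O)NCCCN2C[C@H](C)C[C@H](C)C2)CC1`, gives 0.035 h in this assay, and compound 2, with structure `Cc1oc(-c2c(Cl)cccc2Br)nc1CN1CCC(C(=O)NCCCN2C[C@H](C)C[C@H](C)C2)CC1`, gives 0.0233 h. The two steps that reach compound 3 are both modest and beyond the scatter: a 2.1-fold higher number from compound 1 to compound 3 (0.32 log units; beyond the scatter) and a 3.1-fold higher number from compound 2 to compound 3 (0.50 log units; beyond the scatter). The step between the two halogen-bearing compounds, a 1.5-fold lower number from compound 1 to compound 2 (0.18 log units; within the scatter), stays within the scatter.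

Compound 4 has structure `Cc1ccc(-c2nc(CN3CCC(C(=O)NCCCN4C[C@H](C)C[C@H](C)C4)CC3)c(C)o2)cc1C`. It differs from compound 3 in one place: 3,4-dimethylphenyl in place of 2-fluoro-6-methylphenyl on an aromatic carbon. Within the data shown here, no measured step trades one substituted phenyl lacking halogens for another, so the prior steps bear on this change only loosely: they show that the phenyl substituents can shift the half-life modestly, and nothing more. Compound 4 is therefore expected to stay close to compound 3, with a step of a 1.2-fold lower number from compound 3 to compound 4 (0.09 log units; within the scatter) that need not exceed the scatter. The estimate for compound 4 in this assay is 0.06 h, within a range from 0.025 h to 0.14 h.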

Compound 4, half-life: > 0.5 h
Compound 4: only a limit was reported; the forecaster's own chance of this, stated with the estimate: 5%; at least 8.3-fold (0.92 log units) between middle value and limit.
By their numbers in this assay, from the lowest: compounds 2 and 1 (each within the scatter of the next); then compound 3. At a limit, above all of these: compound 4.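

The value for compound 4 is a limit of the assay, not a number: the limit of > 0.5 h in this assay, at which 1 of the 4 values shown sits.

In this assay, within the data shown here, the phenyl group at this position proves able to move the number much further than the modest steps among the earlier compounds showed, with an at least 6.8-fold higher number from compound 3 to compound 4 (0.83 log units; beyond the scatter), an at least 14-fold higher number from compound 1 to compound 4 (1.15 log units; beyond the scatter) and an at least 21-fold higher number from compound 2 to compound 4 (1.33 log units; beyond the scatter). Of the four phenyl groups shown, 3,4-dimethylphenyl is the only one without halogen, and it stands apart from the three that carry halogen.

The compounds shown leave open whether the step follows from the loss of fluorine or from the 3,4-dimethyl pattern, since both change at once. From the compounds shown here alone, an unsubstituted phenyl or a methoxyphenyl at this position could help to separate the two, and how far compound 4 lies past its limit also stays open.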